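The compounds below may be only part of what the source reports. "The series", "measured", "known", "first", "only" and "open" are said of these compounds alone.

Measured so far:
compound 1 `Cc1ccc2oc(-c3ccccc3)c(O)c(=O)c2c1`, 2 ug/mL in a functional assay on KB cells (Homo sapiens) for cytotoxicity; a lower number here means that less compound is needed, a higher number that more compound is needed for the effect
compound 2 `COc1cc(OC)c(-c2oc3ccccc3c(=O)c2O)cc1OC`, 5 ug/mL in this assay

Compound 1 has the lowest of the two numbers in this assay; the nearest is compound 2, whose number is higher by a gap that lies beyond the scatter, so compound 1 stands as the more potent of the two measured compounds. Compound 3 `Cc1ccc2oc(-c3ccccc3)c(Cl)c(=O)c2c1` has not yet been measured in this assay. It differs from compound 1 in one place: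

chloro in place of hydroxy on an aromatic carbon

Within the data shown here, no pair of measured compounds differing in a single place is available, so there is no measured step to lean on for this change. The hydroxy that leaves brings a hydrogen-bond donor and an acceptor with it; the chloro that enters brings neither. With only the value of compound 1 as anchor, the expectation for compound 3 is a moderate move toward a higher number, of a size at or a little beyond the scatter, as given by a 2.5-fold higher number from compound 1 to compound 3 (0.40 log units; beyond the scatter). Compound 3 is estimated at 5 ug/mL in this assay, with a range from 1.5 ug/mL to 15 ug/mL.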

Compound 3, concentration for half-maximal effect: > 100 ug/mL
Compound 3 gave a limit, no number; the forecaster's own chance of this, stated with the estimate: 10%; middle value at least 20-fold (1.30 log units) from the limit.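

Compound 3 reaches only a limit in this assay, not a number: the limit of > 100 ug/mL in this assay, at which 1 of the 3 values shown sits.

Chloro in place of hydroxy on an aromatic carbon gives an at least 50-fold higher number from compound 1 to compound 3 (1.69 log units; beyond the scatter), the first step in the series that can be read from a single change, and it is large even though its true size stays unknown. The position, ortho to a phenyl group and two atoms from the ring oxygen, is therefore far from indifferent in the core of compound 1: exchanging one heavy atom here, with the hydrogen-bond donor and acceptor of the hydroxy gone, is enough to take the series from a measurable value to a limit.

One replacement cannot show whether the hydroxy itself is needed or whether chloro is the problem, and an amine or a methyl group at this position would help to separate the two. Compound 2 differs from compound 1 in more than one place, so the substituents on the phenyl ring and the methyl group on the fused ring remain unresolved.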